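The source may report more compounds than this note shows. Statements on the series, on what has been measured and on what is new or still open speak of the compounds shown alone.

Compound 1 `CC(OC(=O)Nc1ccccc1)c1cn2ncnc2s1` gives 10000 nM in a functional assay on CHO cells for antagonist activity at metabotropic glutamate receptor 5 (Homo sapiens), read by calcium flux; on this read-out lower numbers stand for stronger inhibition and higher numbers for weaker inhibition. Compound 2 `Cc1c(COC(=O)Nc2ccccc2)sc2ncnn12` stands at a limit of this assay and not at a number, since compound 2 reports > 31600 nM there, (the limit of > 31600 nM in this assay, at which 1 of the 2 values shown sits). Compound 3 `O=C(Nc1ccccc1)OCc1cn2ncnc2s1` differs from compound 2 by hydrogen in place of methyl on an aromatic carbon. Going by the values given here, no measured step covers this change, and with compound 2 sitting at a limit, the step expected from compound 2 to compound 3 in this assay is none beyond the scatter, a number no higher from compound 2 to compound 3 (the limit leaves the size open). Compound 3 is therefore expected to give 31600 nM in this assay, within a range from 10000 nM to 100000 nM, and may again return only a limit.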

Compound 3, half-maximal inhibitory concentration: > 31600 nM
Compound 3 gave a limit, no number (the forecaster's own chance of this, stated with the estimate: 60%); the middle value sits exactly at the limit.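

Going by these compounds alone, the new compound supplies the only readable step so far: hydrogen in place of methyl on the saturated chain carbon bound to an aromatic carbon and an oxygen next to a carbonyl group gives an at least 3.1-fold higher number from compound 1 to compound 3 (0.49 log units; beyond the scatter) in this assay. The methyl on that chain carbon thus goes with the only number among the compounds shown. The step for hydrogen in place of methyl on the aromatic carbon cannot be read, as compound 2 and compound 3 both give limits and not numbers: the limit of > 31600 nM in this assay, at which 2 of the 3 values shown sit.

Open, from the compounds shown here alone, is whether an ethyl group or a second methyl on that chain carbon would lower the number further than compound 1 does. Also open, going by these compounds, is whether an amine or a chlorine on the aromatic carbon would return a number at all.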